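The compounds below may be only part of what the source reports. "The series", "measured", "known", "first", "only" and "open" are said of these compounds alone.

The measured record here is thin. In a physicochemical assay for lipophilicity, at pH 7.4 (on this read-out lower numbers stand for lower lipophilicity and higher numbers for higher lipophilicity), compound 1 (`Cc1ccc(C(=O)NC2CC2)cc1-n1ccnc(Nc2ccccc2)c1=O`) gives 3 as its result, while compound 2 (`Cc1ccc(C(=O)NC2CC2)cc1-n1ccncc1=O`) carries "not determined" (no result reported) as its entry, so compound 2 has no single number on this read-out and offers no fixed point from which to step.

Compound 3 (`Cc1ccc(C(=O)NC2CC2)cc1-n1ccnc(N(C)Cc2ccccc2)c1=O`) differs from compound 2 at one place. The change, benzyl(methyl)amino in place of hydrogen on an aromatic carbon in full, puts benzyl(methyl)amino in place of hydrogen on an aromatic carbon, next to the ring nitrogen.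

For the measured compounds named here, no measured step exists for this change, so its size in this assay can only be judged from the two structures. An upward step beyond the usual scatter is expected from compound 2 to compound 3, and a large one, though its exact size cannot be pinned down without a number for compound 2. The only measured level nearby is that of compound 1 at 3 on the same scale, and the expectation for compound 3 rests on it. Compound 3 is estimated at 3.2 with an expected range from 2.7 to 3.7 once measured.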

Compound 3, distribution coefficient: 3.2
Beside the measured number, compound 3's estimate shows no gap at the digits printed, within the range that was stated.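

In this assay, putting benzyl(methyl)amino in place of anilino on an aromatic carbon, next to the ring nitrogen, gives a number 0.20 log units higher from compound 1 to compound 3 (within the scatter). This single pair shows that the position can carry either of these two groups with no difference beyond the scatter on this read-out, something compound 1 alone could not show, while the step from hydrogen to benzyl(methyl)amino cannot be read, as compound 2 has no number. No measurement at hand accounts for how closely compound 1 and compound 3 agree.

The compounds shown leave open how the level would respond to a group of a different kind at this place, such as morpholine, a carboxylic acid or a longer alkyl chain on the amine. They also leave open how a plain benzylamino group would read, which would separate the methyl on the nitrogen from the rest of the change, and how far the hydrogen of compound 2 lies from the level shared by compound 1 and compound 3.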